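Chloro entering the trifluoromethylphenyl urea arm of compound 1

This account rests on a few compounds, and the source may have more. Where it says the series, first, only, none or still open, it means among the compounds named here.

Compound 1 `O=C(Nc1cccc(-n2cc(-c3ccncc3)c(-c3ccc(Cl)c(O)c3)n2)c1)Nc1cccc(C(F)(F)F)c1` is the parent of this set. In a functional assay on U-251 cells (Homo sapiens) for inhibition, read by sulforhodamine B assay, with a stated time of 48 h (on this read-out higher numbers stand for lower toxicity in this test and lower numbers for higher toxicity in this test), compound 1 gives only a limit, > 32500 nM, and its true number is not known. Compound 1 sits at the limit of > 32500 nM in this assay, at which 1 of the 3 values shown sits. Compound 2 `COc1cc(-c2nn(-c3cccc(NC(=O)Nc4cccc(C(F)(F)F)c4)c3)cc2-c2ccncc2)ccc1Cl` gives 2920 nM in this assay, and compound 3 `O=C(Nc1cccc(-n2cc(-c3ccncc3)c(-c3ccc(Cl)c(O)c3)n2)c1)Nc1cc(C(F)(F)F)cc(C(F)(F)F)c1` gives 2800 nM. Both single changes moved the number down: an at least 11-fold lower number from compound 1 to compound 2 (1.04 log units; beyond the scatter), and an at least 11-fold lower number from compound 1 to compound 3 (1.06 log units; beyond the scatter).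

Compound 4 `O=C(Nc1cccc(-n2cc(-c3ccncc3)c(-c3ccc(Cl)c(O)c3)n2)c1)Nc1ccc(Cl)c(C(F)(F)F)c1` differs from compound 1 in one place: chloro in place of hydrogen on an aromatic carbon. The closest comparison is compound 3, where a second trifluoromethyl entered the same ring of the urea arm and the number fell by a large step. The change to compound 2 went the same way from a different part of the molecule. Two of two measured changes from compound 1 lowered the number, and none raised it. A step in that direction is therefore expected for compound 4 in this assay; its size is uncertain, and compound 1 itself is only a limit, so the starting point is open. Compound 4 is expected at 3500 nM, with a range from 1000 nM to 15000 nM. This estimate means an expected step of an at least 9.2-fold lower number from compound 1 to compound 4 (0.96 log units; beyond the scatter).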

Compound 4, concentration lethal to 50% of the cells: 2740 nM
Beside the measured number, compound 4's estimate is 1.3-fold (0.11 log units) above it; low and high end bracket the measured number.
By their numbers in this assay, from the lowest: compounds 4, 3 and 2 (each within the scatter of the next). At a limit, above all of these: compound 1.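

In this assay, an at least 11-fold lower number from compound 1 to compound 4 (1.07 log units; beyond the scatter), so the urea arm's ring carries a large step with a single chloro ortho to the trifluoromethyl group and para to a large group. Until now, the only change shown on this ring was the entry of a second trifluoromethyl group, and compound 4 shows that this particular group is not required for a step of this kind. All three single changes shown from compound 1, two on the urea arm's ring and one on the oxygen of the chlorophenol ring, lower the number, and none goes against this pattern, while compounds 4, 3 and 2 lie within the scatter of one another.

From the compounds shown here alone, compound 1 remains a limit, so the full size of all three steps stays unknown: the limit of > 32500 nM in this assay, at which 1 of the 4 values shown sits. The compounds shown leave open whether the step depends on chloro itself or would also appear with fluoro, a methyl group, an amine or a carboxylic acid on the same carbon, and whether chloro on this ring would add to the methyl on the oxygen of compound 2.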